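Swapping the chlorophenyl arm for methylphenyl in a pyridine series

The source may report more compounds than this note shows. Statements on the series, on what has been measured and on what is new or still open speak of the compounds shown alone.

compound 1, `Clc1cccc(-c2cc(-c3ccc(Cl)o3)cc(-c3cccs3)n2)c1`: 42%
compound 2, `Clc1ccc(-c2cc(-c3ccc(Cl)o3)cc(-c3ccsc3)n2)cc1`: 29.8%
compound 3, `Clc1cccc(-c2cc(-c3ccc(Cl)o3)cc(-c3ccsc3)n2)c1`: 0%

In an assay on isolated protein for inhibition of DNA topoisomerase 1 (Homo sapiens), tested at 100 uM (a higher number here means a stronger effect of the compound at the concentration tested, a lower number a weaker effect), compound 1 stands highest of the three numbers, ahead of compound 2 by a gap beyond the scatter and far ahead of compound 3. Compound 4, `Cc1ccc(-c2cc(-c3ccc(Cl)o3)cc(-c3cccs3)n2)cc1`, is not yet measured; it differs from compound 1 in one place: 4-methylphenyl in place of 3-chlorophenyl on an aromatic carbon. Going by the values given here, no measured step exchanges a chlorine for a methyl group. The closest guide is a number 29.8 percentage points lower from compound 2 to compound 3 (beyond the scatter), which altered the same phenyl arm, though in a compound carrying thiophen-3-yl rather than thiophen-2-yl; the larger drop a number 42 percentage points lower from compound 1 to compound 3 (beyond the scatter) concerns the thiophene and not this arm. Only a modest step, in either direction, is therefore expected, a number 2 percentage points lower from compound 1 to compound 4 (within the scatter), and compound 4 is estimated at 40%, within 10% to 65%.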

Compound 4, a percentage reported as inhibition, at one concentration (the size of the read-out at that concentration, not a potency): 41.8%
Beside the measured number, compound 4's estimate is 1.8 percentage points below it; measured number inside the range.
By their numbers in this assay, from the lowest: compound 3; then compound 2; then compounds 4 and 1 (each within the scatter of the next).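

In this assay, 4-methylphenyl in place of 3-chlorophenyl gives a number 0.2 percentage points lower from compound 1 to compound 4 (within the scatter), so with thiophen-2-yl on the shared core, this arm tolerates a change of both the group and where it sits on the phenyl ring. The earlier change at this arm, made with thiophen-3-yl present, gave a number 29.8 percentage points lower from compound 2 to compound 3 (beyond the scatter), so a change here does not always leave the read-out in place. Nothing available explains this difference.

The chlorine-for-methyl exchange and the shift in ring position remain inseparable here. Also open, as far as these compounds go, is how a 4-aminophenyl or 4-carboxyphenyl group would behave at this position.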